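This account rests on a few compounds, and the source may have more. Where it says the series, first, only, none or still open, it means among the compounds named here.

Three related compounds have been tested in an assay on isolated protein for inhibition of Amine oxidase [flavin-containing] A (Homo sapiens), read by fluorescence, with stated times of 15 min and 20 min; on this read-out lower numbers stand for stronger inhibition and higher numbers for weaker inhibition. Compound 1 `Cc1ccc(C2=NN(C(=O)CN3CCCCC3)C(c3ccccc3O)C2)cc1` gives 11300 nM. Compound 2 `O=C(CN1CCCCC1)N1N=C(c2ccc(F)cc2)CC1c1ccccc1O` gives 8020 nM in this assay. Compound 3 `Cc1ccc(C2=NN(C(=O)CN3CCCCC3)C(c3cc(Cl)ccc3O)C2)cc1` gives 14400 nM in this assay. The three numbers lie close together. The change from compound 1 to compound 2 is fluoro in place of methyl on an aromatic carbon, and it produced a 1.4-fold lower number from compound 1 to compound 2 (0.15 log units; within the scatter). The change from compound 1 to compound 3 is chloro in place of hydrogen on an aromatic carbon, and it produced a 1.3-fold higher number from compound 1 to compound 3 (0.11 log units; within the scatter). Neither step can be told apart from the ordinary variation of repeated measurements, so among these three compounds no one stands out as stronger or weaker than the others.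

Compound 4 `O=C(CN1CCCCC1)N1N=C(c2ccc(F)cc2)CC1c1cc(Cl)ccc1O` has not yet been measured. It differs from compound 3 by fluoro in place of methyl on an aromatic carbon. For the measured compounds named here, this is the same change as the one from compound 1 to compound 2, at the same place, on an aromatic carbon of a six-membered aromatic ring of carbon only, para to a large group. The difference between the two cores on which it is made is chloro in place of hydrogen on an aromatic carbon. Since that earlier example of the change stayed within the scatter, a step of similar size is expected here, a 1.4-fold lower number from compound 3 to compound 4 (0.14 log units; within the scatter), because the one comparable case gave a 1.4-fold lower number from compound 1 to compound 2 (0.15 log units; within the scatter). In this assay compound 4 is therefore estimated at 10500 nM, with a likely range from 5000 nM to 22000 nM.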

Compound 4, half-maximal inhibitory concentration: 3720 nM
The estimate for compound 4 lay 2.8-fold (0.45 log units) above the measured number, and the stated range ends above it.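

In this assay, fluoro in place of methyl gave a 3.9-fold lower number from compound 3 to compound 4 (0.59 log units; beyond the scatter) on the core that carries the chloro group, and this step does not match the earlier example on the core without chloro: the same change on two cores in this assay, a 1.4-fold lower number (0.15 log units; within the scatter) from compound 1 to compound 2 and a 3.9-fold lower number (0.59 log units; beyond the scatter) from compound 3 to compound 4, 2.7-fold (0.44 log units) apart, beyond the scatter of two such steps. Seen from the other side, chloro in place of hydrogen gave a 2.2-fold lower number from compound 2 to compound 4 (0.33 log units; beyond the scatter) on the core that carries fluoro, and this step also differs from its earlier example on the core with methyl: the same change on two cores in this assay, a 1.3-fold higher number (0.11 log units; within the scatter) from compound 1 to compound 3 and a 2.2-fold lower number (0.33 log units; beyond the scatter) from compound 2 to compound 4, 2.7-fold (0.44 log units) apart, beyond the scatter of two such steps. Together these pairs show that the two changes do not simply add up here, so the size of either step cannot be carried unchanged from one core to the other, but a single set of four compounds cannot show why this happens or whether it would happen with other groups.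

On these data alone, it remains open whether a similar dependence between the two places would appear with bromo or methoxy in place of the chloro group, or with a nitrile in place of the fluoro group. The compounds shown also leave open whether these steps would keep their size with a longer chain leading to the amine or with a different amine at its end.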